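Extending the ether arm of compound 2 by one methoxy unit

The source may report more compounds than this note shows. Statements on the series, on what has been measured and on what is new or still open speak of the compounds shown alone.

Compound 2 `COC/C1=C/C[C@](C)(CCC=C(C)C)/C=C/[C@@H](OC(=O)C=C(C)C)[C@](C)(O)/C=C/C1=O` gives 3070 nM in a functional assay on HL-60 cells (Homo sapiens) for antiproliferative activity, read by MTT assay, with a stated time of 48 h (a higher number here means a weaker inhibitor, a lower number a stronger inhibitor), the second highest of three numbers. Compound 1 `COC/C1=C/C[C@](C)(CCC=C(C)C)/C=C/[C@@H](OC(=O)C=C(C)C)[C@](C)(OC)/C=C/C1=O` gives 4050 nM, and the step of a 1.3-fold lower number from compound 1 to compound 2 (0.12 log units; within the scatter) lies within the scatter. Compound 3 `CC(C)=CCC[C@]1(C)/C=C/[C@@H](OC(=O)C=C(C)C)[C@](C)(O)/C=C/C(=O)/C(CN2CCCC2)=C\C1` gives 160 nM, and the step of a 19-fold lower number from compound 2 to compound 3 (1.28 log units; beyond the scatter) is large. Compound 4 `COCOC/C1=C/C[C@](C)(CCC=C(C)C)/C=C/[C@@H](OC(=O)C=C(C)C)[C@](C)(O)/C=C/C1=O` differs from compound 2 by methoxy in place of hydrogen on a saturated chain carbon bound to an oxygen on a saturated carbon. The step on the same arm, from methoxy to pyrrolidin-1-yl, was large, but that change brought in a nitrogen ring; the step on an oxygen elsewhere, methyl to hydrogen, stayed within the scatter. A small ether extension is therefore expected to move the number little: for compound 4 the estimate is 2600 nM (from 1200 nM to 6000 nM), a step of a 1.2-fold lower number from compound 2 to compound 4 (0.07 log units; within the scatter).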

Compound 4, half-maximal inhibitory concentration: 2840 nM
Compound 4: middle estimate off by 1.1-fold (0.04 log units), on the low side, and the stated range covers the measured number.
By their numbers in this assay, from the lowest: compound 3; then compounds 4, 2 and 1 (each within the scatter of the next).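

In this assay, lengthening the arm from methoxymethyl to (methoxymethoxy)methyl leaves the number within the scatter (a 1.1-fold lower number from compound 2 to compound 4 (0.03 log units; within the scatter)), so this position accepts the larger ether without a readable change. The gap to the pyrrolidin-1-yl arm stays large (an 18-fold higher number from compound 3 to compound 4 (1.25 log units; beyond the scatter)), which shows that a longer ether arm alone does not match that result.

From the compounds shown here alone, whether a dimethylamino or morpholin-4-yl arm would behave like compound 3 remains open, as does the effect of a longer ether chain. No available evidence bears on what underlies the difference between these arms.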